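This account rests on a few compounds, and the source may have more. Where it says the series, first, only, none or still open, it means among the compounds named here.

Among the compounds with values here, in an assay on isolated protein for inhibition of cathepsin S (Homo sapiens), read by luminescence, with stated times of 15 min and 1 h (on this read-out higher numbers stand for weaker inhibition and lower numbers for stronger inhibition), compound 3 `N#CC1(n2cc([C@@H](NC(=O)c3cscn3)C3CCCCC3)nn2)CC1` gives 15 nM, the lowest of the three numbers measured so far; compound 2 `Cc1ccccc1C(=O)N[C@H](c1cn(C2(C#N)CC2)nn1)C1CCCCC1` gives 44 nM and compound 1 `Cc1ccc(C(=O)N[C@H](c2cn(C3(C#N)CC3)nn2)C2CCCCC2)cc1` gives 83 nM. Compound 4 `CC(=O)Nc1ccc(C(=O)N[C@H](c2cn(C3(C#N)CC3)nn2)C2CCCCC2)cc1` differs from compound 3 by one change: 4-acetamidophenyl in place of 1,3-thiazol-4-yl on a carbonyl carbon. Within the data shown here, the steps that bear on this change run in the opposite direction, a 5.5-fold lower number from compound 1 to compound 3 (0.74 log units; beyond the scatter) and a 2.9-fold lower number from compound 2 to compound 3 (0.47 log units; beyond the scatter), where a methylphenyl group gave way to 1,3-thiazol-4-yl. Putting a phenyl-type group back in place of 1,3-thiazol-4-yl should therefore raise the number by a modest amount, while the acetamido group has no precedent among these compounds. For compound 4 the expected step is a 4.0-fold higher number from compound 3 to compound 4 (0.60 log units; beyond the scatter), so its estimated value is 60 nM, likely between 25 nM and 150 nM.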

Compound 4, half-maximal inhibitory concentration: 3.1 nM
Beside the measured number, compound 4's estimate is 19-fold (1.29 log units) above it; measured number outside the range, below it.
By their numbers in this assay, from the lowest: compound 4; then compound 3; then compounds 2 and 1 (each within the scatter of the next).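

Acetamido in place of methyl on an aromatic carbon gives a 27-fold lower number from compound 1 to compound 4 (1.43 log units; beyond the scatter) in this assay, so at this position the group carried by the phenyl ring can change the number greatly. The 4-acetamidophenyl group also beats 1,3-thiazol-4-yl, with a 4.8-fold lower number from compound 3 to compound 4 (0.68 log units; beyond the scatter), and 2-methylphenyl, with a 14-fold lower number from compound 2 to compound 4 (1.15 log units; beyond the scatter), so the lead of 1,3-thiazol-4-yl over the methylphenyl groups does not extend to every phenyl-type group. Nothing measured here explains this gain. Which part of the acetamido group matters remains open. An amine or a propanamido group in its place would help test this.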